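The source may hold more compounds than are shown below. What is called first, only, known or untested is meant among the compounds shown, and "the series" means these compounds.

Compound 3 `OC(CCn1nc2c(Br)c(Br)c(Br)c(Br)c2n1)c1ccc(Br)cc1` carries the shared core of this small set together with a 4-bromophenyl group. In a functional assay on CCRF-CEM cells (Homo sapiens) for antiproliferative activity, read by MTT assay, with a stated time of 48 h, tested at 50 uM (a higher number here means a weaker effect of the compound at the concentration tested, a lower number a stronger effect), compound 3 gives 0%, level with compound 1 `OC(CCn1nc2c(Br)c(Br)c(Br)c(Br)c2n1)c1cccc(Br)c1`, which gives 0%, and with compound 2 `OC(CCn1nc2c(Br)c(Br)c(Br)c(Br)c2n1)c1cccc(Cl)c1`, which gives 0%. Compound 4 `OC(CCn1nc2c(Br)c(Br)c(Br)c(Br)c2n1)c1ccc(Cl)cc1` differs from compound 3 by chloro in place of bromo on an aromatic carbon. The very same exchange of chloro for bromo was already made once: no change at the digits printed from compound 1 to compound 2 (within the scatter). The remaining steps, no change at the digits printed from compound 1 to compound 3 (within the scatter) and no change at the digits printed from compound 2 to compound 3 (within the scatter), were flat as well. Since every measured compound sits at one level, the step expected here is no change at the digits printed from compound 3 to compound 4 (within the scatter), nothing beyond the scatter. Compound 4 is therefore estimated to give 0%, within a range from 0% to 10%.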

Compound 4, a percentage reported as activity, at one concentration (the size of the read-out at that concentration, not a potency): 0%
Compound 4: the middle estimate sits on the measured number at the digits printed; the range from low to high includes it.
By their numbers in this assay, from the lowest: compounds 1, 2, 3 and 4 (each within the scatter of the next).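

In this assay, chloro for bromo on an aromatic carbon para to a large group gives no change at the digits printed from compound 3 to compound 4 (within the scatter), so this exchange now has a second reading on a different ring placement: the same change on two cores in this assay, no change at the digits printed (within the scatter) from compound 1 to compound 2 and no change at the digits printed (within the scatter) from compound 3 to compound 4, 0 percentage points apart, within the scatter of two such steps The 4-chlorophenyl group also completes the set, with no change at the digits printed from compound 2 to compound 4 (within the scatter) and no change at the digits printed from compound 1 to compound 4 (within the scatter), so 3-bromophenyl, 3-chlorophenyl, 4-bromophenyl and 4-chlorophenyl all read alike here.

With all four compounds at one level, these data cannot show whether any group at this position can shift the read-out. Going by these compounds, whether an amine or a carboxylic acid on that ring, or a plain phenyl, would read differently stays open.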